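Methoxy on the phenyl of compound 3

This account rests on a few compounds, and the source may have more. Where it says the series, first, only, none or still open, it means among the compounds named here.

In a functional assay on MCF7 cells (Homo sapiens) for inhibition, read by MTT assay, with a stated time of 48 h (a higher number here means a weaker inhibitor, a lower number a stronger inhibitor), compound 1 (`O=C(Nc1cnn(-c2ccccc2)c1)c1cccc(NS(=O)(=O)c2ccccc2)c1`) gives 4320 nM, compound 2 (`Cc1ccc(-n2cc(NC(=O)c3cccc(NS(=O)(=O)c4ccccc4)c3)cn2)cc1`) gives 1690 nM and compound 3 (`O=C(Nc1cnn(-c2ccccc2)c1)c1cccc(NS(=O)(=O)c2ccc(Cl)cc2)c1`) gives 3130 nM. Compound 3 lies within the scatter of both compound 1 and compound 2, although those two stand apart beyond it. Compound 4 (`COc1cccc(-n2cc(NC(=O)c3cccc(NS(=O)(=O)c4ccc(Cl)cc4)c3)cn2)c1`) differs from compound 3 in one place, phenyl to 3-methoxyphenyl: methoxy in place of hydrogen on an aromatic carbon. Within the data shown here, two measured steps bear on this change. Methyl on the same phenyl gave a 2.6-fold lower number from compound 1 to compound 2 (0.41 log units; beyond the scatter), while chloro elsewhere on the shared core gave a 1.4-fold lower number from compound 1 to compound 3 (0.14 log units; within the scatter). Among the measured compounds shown here, no methoxy compound has been measured yet, so both steps are only loose guides. For the measured compounds named here, a small shift toward a lower number is expected, with no step clearly beyond the scatter. The expected step is a 1.4-fold lower number from compound 3 to compound 4 (0.15 log units; within the scatter). Compound 4 is estimated at 2200 nM, with an expected range of 800 nM to 5500 nM.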

Compound 4, half-maximal inhibitory concentration: 9430 nM
Compound 4: middle estimate off by 4.3-fold (0.63 log units), on the low side; the measured number lies above the stated range.
By their numbers in this assay, from the lowest: compounds 2, 3 and 1 (each within the scatter of the next, the first and the last beyond it); then compound 4.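

Methoxy meta to a large group on this phenyl gives a 3.0-fold higher number from compound 3 to compound 4 (0.48 log units; beyond the scatter) in this assay and so moves the number the opposite way to methyl on the same phenyl, which gave a 2.6-fold lower number from compound 1 to compound 2 (0.41 log units; beyond the scatter) on the core without chloro. Both steps lie beyond the scatter, so adding a group to this phenyl does not lead to a lower number in every case, and the outcome depends on the change made there. Nothing available explains the direction of the methoxy step.

As far as these compounds go, the two steps differ in the group, in its place on the phenyl and in the compound that carries it, so it remains open which of these sets the direction. Methoxy on the core of compound 1, or a hydroxy group or an amine at the same place, would help separate these factors.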